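Swapping a Thiazole for a Pyridine on a Flavone Chain

The source may report more compounds than this note shows. Statements on the series, on what has been measured and on what is new or still open speak of the compounds shown alone.

Of the compounds shown here, three sharing the same core have been tested in a functional assay on MGC-803 cells (Homo sapiens) for antiproliferative activity, read by MTT assay, with a stated time of 48 h; on this read-out lower numbers stand for stronger inhibition and higher numbers for weaker inhibition. Compound 1 `COc1cc(OC)c2c(=O)c(OCCCOc3ccccc3/C=C/C(=O)/C=C/c3ccccn3)c(-c3cc(OC)c(OC)c(OC)c3)oc2c1` gives 560 nM. Compound 2 `COc1cc(OC)c2c(=O)c(OCCCOc3ccccc3/C=C/C(=O)/C=C/c3scnc3C)c(-c3cc(OC)c(OC)c(OC)c3)oc2c1` gives 5570 nM. Compound 3 `COc1cc(OC)c2c(=O)c(OCCCCOc3ccc(/C=C/C(=O)/C=C/c4scnc4C)cc3)c(-c3cc(OC)c(OC)c(OC)c3)oc2c1` gives 54600 nM, the highest number of the three.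

Compounds 2 and 1 differ in one place: pyridin-2-yl in place of 4-methyl-1,3-thiazol-5-yl on a double-bonded chain carbon bound to a double-bonded chain carbon. That change produced a 9.9-fold lower number from compound 2 to compound 1 (1.00 log units; beyond the scatter).

The same change is now applied to compound 3, giving compound 4 `COc1cc(OC)c2c(=O)c(OCCCCOc3ccc(/C=C/C(=O)/C=C/c4ccccn4)cc3)c(-c3cc(OC)c(OC)c(OC)c3)oc2c1`, which differs from compound 3 as pyridin-2-yl in place of 4-methyl-1,3-thiazol-5-yl on a double-bonded chain carbon bound to a double-bonded chain carbon. The cores of compound 3 and compound 2 are not the same, and the difference between the two cores is not broken down here, so the step may not carry over exactly.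

Among the measured compounds shown here, still, the one measured example is the best guide available. Compound 4 is therefore expected to show a 9.1-fold lower number from compound 3 to compound 4 (0.96 log units; beyond the scatter), resting on the step of a 9.9-fold lower number from compound 2 to compound 1 (1.00 log units; beyond the scatter) seen in the matched pair. The estimate for compound 4 in this assay is 6000 nM, with a plausible range from 1500 nM to 25000 nM. For the measured compounds named here, the range is wide: the surrounding core of compound 3 differs from that of compound 2, and no step between those two cores is given.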

Compound 4, half-maximal inhibitory concentration: 1960 nM
Beside the measured number, compound 4's estimate is 3.1-fold (0.49 log units) above it; low and high end bracket the measured number.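

In this assay, placing pyridin-2-yl where 4-methyl-1,3-thiazol-5-yl stood gives a 28-fold lower number from compound 3 to compound 4 (1.44 log units; beyond the scatter), so the change points the same way on both cores shown. Its size, however, does not carry over unchanged: the same change on two cores in this assay, a 9.9-fold lower number (1.00 log units; beyond the scatter) from compound 2 to compound 1 and a 28-fold lower number (1.44 log units; beyond the scatter) from compound 3 to compound 4, 2.8-fold (0.45 log units) apart, beyond the scatter of two such steps. These two pairs show that the direction held on both cores, but they cannot show which part of the core alters the size of the step, or whether the direction would hold on any other core in the series.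

The compounds shown leave open whether other rings at this end of the chain, such as phenyl, pyridin-3-yl or furan-2-yl, would give numbers like those of the pyridin-2-yl compounds. They also leave open how an amine or a carboxylic acid added to the pyridin-2-yl ring would affect the number on each core.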